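Swapping the pendant aryl group on an aminothiophene core

A few compounds are considered here, and "the series" means these few. Any claim that something is new, unique, unknown or untested is made for them only; others in the source may bear on it.

Of the compounds shown here, three that share one core have been tested for their ability to slow the growth of mouse tumour cells. Compound 1 `COc1ccc(-c2cc(N)c(C(=O)c3cc(OC)c(OC)c(OC)c3)s2)cc1OC` gives 72 nM in a functional assay on FM3A cells (Mus musculus) for antiproliferative activity; a higher number here means a weaker inhibitor, a lower number a stronger inhibitor. Compound 2 `COc1cc(C(=O)c2sc(-c3ccc([N+](=O)[O-])cc3)cc2N)cc(OC)c1OC` gives 64 nM in this assay, and compound 3 `COc1cc(C(=O)c2sc(-c3ccc(Cl)cc3)cc2N)cc(OC)c1OC` gives 90 nM. Among these three numbers compound 1 stands second highest; its nearest neighbour is compound 2 with a 1.1-fold lower number from compound 1 to compound 2 (0.05 log units; within the scatter), and its furthest is compound 3 with a 1.3-fold higher number from compound 1 to compound 3 (0.10 log units; within the scatter). Compound 2 and compound 3 also sit close together, a 1.4-fold higher number from compound 2 to compound 3 (0.15 log units; within the scatter).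

Compound 4 `COc1cc(C(=O)c2sc(-c3ccc(I)cc3)cc2N)cc(OC)c1OC` has not yet been measured. It differs from compound 1 in one place: 4-iodophenyl in place of 3,4-dimethoxyphenyl on an aromatic carbon. For the measured compounds named here, the step that bears most directly on this change is the one from compound 1 to compound 3, where a single halogen-bearing ring also took the place of the 3,4-dimethoxyphenyl and the number barely moved. The step to compound 2 tells the same story. The expected step is therefore small, a 1.2-fold higher number from compound 1 to compound 4 (0.07 log units; within the scatter), with no clear direction. Compound 4 is estimated at 85 nM, within a range from 40 nM to 180 nM.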

Compound 4, half-maximal inhibitory concentration: 420 nM
Compound 4: middle estimate off by 4.9-fold (0.69 log units), on the low side; measured number above the stated range.
By their numbers in this assay, from the lowest: compounds 2, 1 and 3 (each within the scatter of the next); then compound 4.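

In this assay this position proves less tolerant than the first three compounds suggested: iodo in place of chloro gives a 4.7-fold higher number from compound 3 to compound 4 (0.67 log units; beyond the scatter), even though the values for compounds 1, 2 and 3 all lie within the scatter of one another. The other two steps agree, with a 5.8-fold higher number from compound 1 to compound 4 (0.77 log units; beyond the scatter) and a 6.6-fold higher number from compound 2 to compound 4 (0.82 log units; beyond the scatter), so the 4-iodophenyl group stands apart from all three earlier aryl groups, and exchanging one halogen for another on this ring can be enough to weaken the compound. Nothing available here explains this loss of activity.

On these data alone, it remains open whether a 4-bromophenyl group would behave like the 4-chlorophenyl group or like the 4-iodophenyl group. A 4-methylphenyl or 4-aminophenyl group at the same place would show whether iodo is a lone exception.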